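Aryl exchange at the double-bonded chain carbon

The source may hold more compounds than are shown below. What is called first, only, known or untested is meant among the compounds shown, and "the series" means these compounds.

Compound 1 `Cc1ccc(/C=C2\S/C(=N\c3csc(-c4ccc(Cl)cc4)c3)NC2=O)cc1`: 1000 nM
Compound 2 `COc1ccc(/C=C2\S/C(=N\c3csc(-c4ccc(Cl)cc4)c3)NC2=O)cc1OC`: 1700 nM

Among the measured compounds shown here, in a functional assay on HCT-116 cells (Homo sapiens) for cytotoxicity, read by MTT assay, with a stated time of 72 h (on this read-out higher numbers stand for weaker inhibition and lower numbers for stronger inhibition), compound 2 gives 1700 nM, the higher of the two numbers; the only step measured, a 1.7-fold higher number from compound 1 to compound 2 (0.23 log units; within the scatter), lies within the scatter. Compound 3 `O=C1N/C(=N/c2csc(-c3ccc(Cl)cc3)c2)S/C1=C\c1ccc(F)cc1` differs from compound 2 by 4-fluorophenyl in place of 3,4-dimethoxyphenyl on a double-bonded chain carbon bound to a double-bonded ring carbon. For the measured compounds named here, the one step that bears on this change is the aryl exchange from compound 1 to compound 2, which stayed within the scatter, so no step beyond the scatter is expected here in this assay. Compound 3 is therefore estimated at 1200 nM, between 500 nM and 3000 nM, a step of a 1.4-fold lower number from compound 2 to compound 3 (0.15 log units; within the scatter) that is expected to stay within the scatter.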

Compound 3, half-maximal inhibitory concentration: 7400 nM
Estimate against measurement, compound 3: 6.2-fold (0.79 log units) below; the whole stated range lies below it.
By their numbers in this assay, from the lowest: compounds 1 and 2 (each within the scatter of the next); then compound 3.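

In this assay, this position turned out not to be indifferent to the aryl group: 4-fluorophenyl in place of 3,4-dimethoxyphenyl gives a 4.4-fold higher number from compound 2 to compound 3 (0.64 log units; beyond the scatter), and fluoro in place of methyl on an aromatic carbon gives a 7.4-fold higher number from compound 1 to compound 3 (0.87 log units; beyond the scatter). Both steps lie beyond the scatter, so compound 3 is the weakest of the three, while compound 1 and compound 2 remain within the scatter of each other. Nothing shown here accounts for this difference. On these data alone, it remains open whether chloro or bromo in place of fluoro would behave like fluoro or like methyl. A dimethylamino group or a carboxylic acid on this aromatic ring is also untested among the compounds shown.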